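A few compounds are considered here, and "the series" means these few. Any claim that something is new, unique, unknown or untested is made for them only; others in the source may bear on it.

Compound 1, `CC(=O)c1ccc2[nH]c(-c3ccc(Cl)cc3)nc2c1`: in an ADME assay on MDBK cells (Bos taurus) for cytotoxicity, read by MTT assay, with a stated time of 96 h (on this read-out higher numbers stand for lower toxicity in this test and lower numbers for higher toxicity in this test), compound 1 gives > 100000 nM, which is a limit of the assay and not a number.
Compound 2, `CC(=O)c1ccc2[nH]c(-c3ccc(C(F)(F)F)cc3)nc2c1`: in this assay compound 2 gives > 100000 nM, again a limit of the assay.
Compound 3, `C/C(=N\NC(N)=O)c1ccc2c(c1)nc(-c1ccc(Cl)cc1)n2C1CCCCC1`: in this assay compound 3 gives > 100000 nM, again a limit of the assay.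

Compounds 1 and 2 differ in one place: trifluoromethyl in place of chloro on an aromatic carbon. The step in this assay is a step that the two limits leave unreadable from compound 1 to compound 2. It cannot be read because of the limit of > 100000 nM in this assay, at which 3 of the 3 values shown sit; the two values only show that both compounds sit at that limit. Compound 3 carries a different core from compound 1, and the difference between the two cores is not broken down here.

Compound 4, `C/C(=N\NC(N)=O)c1ccc2c(c1)nc(-c1ccc(C(F)(F)F)cc1)n2C1CCCCC1`, has not yet been measured. It differs from compound 3 by trifluoromethyl in place of chloro on an aromatic carbon. The surroundings of the change are described in the same words as for the change from compound 1 to compound 2, so the two are the same change, occurring twice among the four compounds.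

The expectation for compound 4 rests on compound 3, which in this assay gives > 100000 nM, a limit. Going by the values given here, with the only earlier instance of the change unreadable, compound 4 is expected to give 150000 nM, within an estimated range from 50000 nM to 500000 nM. The expected step is a step that the limit leaves unreadable from compound 3 to compound 4, an estimate only. Most likely the assay will again report only a limit.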

Compound 4, half-maximal cytotoxic concentration: > 100000 nM
Compound 4: no number, only a limit; the forecaster's own chance of this, stated with the estimate: 85%; the middle value is on the limit's open side.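

The step from compound 3 to compound 4 cannot be read in this assay, because both compounds sit at a limit of the assay and neither gives a number: the limit of > 100000 nM in this assay, at which 4 of the 4 values shown sit.

The compounds shown leave open how far each of the four lies past that limit, and so whether trifluoromethyl in place of chloro changes this read-out at all.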